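Chloro in Place of Fluoro, Tested a Second Time

A few compounds are considered here, and "the series" means these few. Any claim that something is new, unique, unknown or untested is made for them only; others in the source may bear on it.

Compound 1, `O=C(CSc1nc(Nc2ccccc2)c2ccccc2n1)Nc1ccccc1F`, and compound 2, `O=C(CSc1nc(Nc2ccccc2)c2ccccc2n1)Nc1ccccc1Cl`, share one core and differ in a single spot, where compound 2 carries chloro in place of fluoro on an aromatic carbon. In a functional assay on NCI-H1975 cells (Homo sapiens) for inhibition, read by MTT assay, with a stated time of 72 h (on this read-out higher numbers stand for weaker inhibition and lower numbers for stronger inhibition), compound 1 gives 9350 nM. In this assay compound 2 gives 9610 nM. The step between them is a 1.0-fold higher number from compound 1 to compound 2 (0.01 log units; within the scatter), so the two numbers cannot be told apart.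

Compound 3, `C=CC(=O)Nc1cccc(NC(=O)CSc2nc(Nc3ccc(F)cc3)c3ccccc3n2)c1`, is built on a different core; how its core differs from that of compound 1 is not broken down here. In this assay compound 3 gives 4430 nM, the lowest of the three numbers, with compound 1 and compound 2 both standing beyond the scatter above it.

Compound 4, `C=CC(=O)Nc1cccc(NC(=O)CSc2nc(Nc3ccc(Cl)cc3)c3ccccc3n2)c1`, has not yet been measured. It differs from compound 3 by chloro in place of fluoro on an aromatic carbon. This is the same kind of change as that from compound 1 to compound 2, but the place is not the same: in compound 1 the fluoro sits ortho to a large group, whereas in compound 3 it sits para to a large group. Among the compounds with values here, the only guide here is the earlier pair, and because a 1.0-fold higher number from compound 1 to compound 2 (0.01 log units; within the scatter), the expected step is a 1.0-fold higher number from compound 3 to compound 4 (0.01 log units; within the scatter). The expected value for compound 4 in this assay is 4500 nM, with a likely range from 2200 nM to 9000 nM.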

Compound 4, half-maximal inhibitory concentration: 7580 nM
For compound 4 the middle estimate is 1.7-fold (0.23 log units) below the measured one, and the stated range covers the measured number.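

On the core of compound 3, the step for chloro in place of fluoro is a 1.7-fold higher number from compound 3 to compound 4 (0.23 log units; within the scatter), so in this assay compound 3 and compound 4 cannot be told apart. Set beside the earlier pair, the change reads the same on both cores, since the gap between the two steps is no larger than repeated measurements would be expected to produce: the same change on two cores in this assay, a 1.0-fold higher number (0.01 log units; within the scatter) from compound 1 to compound 2 and a 1.7-fold higher number (0.23 log units; within the scatter) from compound 3 to compound 4, 1.7-fold (0.22 log units) apart, within the scatter of two such steps. This shows that, in these two pairs and this one assay, exchanging fluoro for chloro gave no step beyond the scatter, but two pairs make no general rule, the change sits at a different place on each core, and a swap this small with no clear effect says nothing about why the numbers stay close.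

The compounds shown leave open what a group other than these two halogens, such as methoxy, an amine or a nitrile, would do para to a large group on the ring of compound 3. Also open, from the compounds shown here alone, is whether a larger group at that place, such as trifluoromethyl, would give a step beyond the scatter on either core.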